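Swapping a Chlorinated Ring for a Phenol in a Dienone Pair

This account rests on a few compounds, and the source may have more. Where it says the series, first, only, none or still open, it means among the compounds named here.

Two measured compounds share a dienone core. Compound 1 `COc1cccc(/C=C2\CCC/C(=C\c3ccc(Cl)c(Cl)c3)C2=O)c1OC` carries 3,4-dichlorophenyl and 2,3-dimethoxyphenyl arms; in a functional assay on HT-1080 cells (Homo sapiens) for cytotoxicity, read by MTT assay, with a stated time of 72 h (on this read-out higher numbers stand for weaker inhibition and lower numbers for stronger inhibition), compound 1 gives 10800 nM. Compound 2 `COc1ccc(/C=C2\CCC/C(=C\c3cccc(Cl)c3)C2=O)cc1OC` pairs a 3-chlorophenyl arm with a 3,4-dimethoxyphenyl arm, and in this assay compound 2 gives 4900 nM, the lower of the two numbers, a gap from compound 1 that lies beyond the scatter.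

Compound 3 `COc1ccc(/C=C2\CCC/C(=C\c3ccc(O)cc3)C2=O)cc1OC` has not been tested. It differs from compound 2 by one change: 4-hydroxyphenyl in place of 3-chlorophenyl on a double-bonded chain carbon bound to a double-bonded ring carbon. For the measured compounds named here, no measured step involving this change exists, so the direction is uncertain; with a hydroxyl entering where chlorine left, the writer expects a modest weakening, a step of a 1.8-fold higher number from compound 2 to compound 3 (0.26 log units; within the scatter) in this assay somewhat beyond the scatter. Compound 3 is therefore estimated at 9000 nM, within a range of 3000 nM to 30000 nM.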

Compound 3, half-maximal inhibitory concentration: 16800 nM
Compound 3: the middle estimate sits 1.9-fold (0.27 log units) below what was measured; the range from low to high includes it.
By their numbers in this assay, from the lowest: compound 2; then compounds 1 and 3 (each within the scatter of the next).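

Compounds 1 and 2 differ in more than one place, so they could not show what this position alone contributes; compound 3 supplies the first such reading. With the 3,4-dimethoxyphenyl arm and the shared core held constant, 4-hydroxyphenyl in place of 3-chlorophenyl gives a 3.4-fold higher number from compound 2 to compound 3 (0.54 log units; beyond the scatter) in this assay, a weakening beyond the scatter, so this position does respond to the choice of arm. Nothing in the data shown accounts for the size or direction of this step.

This single exchange removes chlorine and introduces hydroxyl together, so the compounds shown leave open how much of the step belongs to each. On these data alone, how plain phenyl, 4-chlorophenyl or 4-aminophenyl would compare at this position also remains open.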